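A few compounds are considered here, and "the series" means these few. Any claim that something is new, unique, unknown or untested is made for them only; others in the source may bear on it.

Compound 3 `Cc1cc(CCC(=O)O)ccc1-c1noc(-c2ccc(OC(C)C)c(F)c2)n1` is the starting point of this account. In a functional assay on CHO cells with sphingosine 1-phosphate receptor 4 (Homo sapiens) as the target, read by GTPgammaS binding (a higher number here means that more compound is needed for the effect, a lower number that less compound is needed), compound 3 gives > 10000 nM, which is a limit of the assay and not a number. Its two relatives stand the same way. Compound 1 `Cc1cc(CCC(=O)O)ccc1-c1noc(-c2ccc(OC(C)C)c(C(F)(F)F)c2)n1` gives in this assay > 10000 nM, also a limit. Compound 2 `COc1ccc(-c2nc(-c3ccc(CCC(=O)O)cc3C)no2)cc1C(F)(F)F` gives in this assay > 10000 nM, again a limit. Among the measured compounds shown here, the step that the two limits leave unreadable from compound 1 to compound 2 and the step that the two limits leave unreadable from compound 1 to compound 3 therefore have no readable size, and the only thing the numbers show is the limit of > 10000 nM in this assay, at which 3 of the 3 values shown sit. Compound 4 `Cc1cc(CCC(=O)O)ccc1-c1noc(-c2ccc(OC(C)C)c(Cl)c2)n1` differs from compound 3 by chloro in place of fluoro on an aromatic carbon. Neither measured step bears on this exchange in a usable way, since both are unreadable, so no direction can be taken from them. The expectation for compound 4 is that this assay will again report only the limit, which corresponds to an expected step of a number no higher from compound 3 to compound 4 (the limit leaves the size open). Compound 4 is accordingly estimated at 10000 nM, with a range from 3000 nM to 30000 nM.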

Compound 4, half-maximal effective concentration: > 10000 nM
Compound 4 gave a limit, no number (the forecaster's own chance of this, stated with the estimate: 85%); the middle value sits exactly at the limit.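

The limit recurs for compound 4, so the steps to compound 4 from compound 3 and from compound 1 cannot be read, and what remains is this: the limit of > 10000 nM in this assay, at which 4 of the 4 values shown sit.

The compounds shown leave open how chloro, fluoro and trifluoromethyl at this place compare in this assay, since none of them gives a number there.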